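The source may hold more compounds than are shown below. What is called first, only, known or untested is meant among the compounds shown, and "the series" means these compounds.

Compound 3, `C#CCN(C)CCCOc1cc(NC(=O)CCCCCCC(=O)NO)c(Cl)cc1Cl`, gives the highest of the numbers recorded in an assay on GL26 cells for inhibition of Amine oxidase [flavin-containing] A (Homo sapiens), read by scintillation counting, with a stated time of 20 min (on this read-out higher numbers stand for weaker inhibition and lower numbers for stronger inhibition), at 430 nM. Its nearest neighbour among the measured compounds is compound 2, `C#CCN(C)CCCOc1cc(NC(=O)CCCCCCCC(=O)NO)ccc1Cl`, which in this assay gives 20 nM; the two differ in chain length and in the ring substitution at once. Compound 1, `C#CCN(C)CCCOc1cc(NC(=O)CCCCCCCCC(=O)NO)ccc1Cl`, reaches only the limit of this assay, < 0.1 nM, and that value is a limit rather than a number; the limit of < 0.1 nM in this assay, at which 1 of the 3 values shown sits, marks where it sits.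

Compound 4, `C#CCN(C)CCCOc1cc(NC(=O)CCCCCCC(=O)NO)ccc1Cl`, differs from compound 3 by hydrogen in place of chloro on an aromatic carbon. For the measured compounds named here, the only measured step available, an at least 200-fold higher number from compound 1 to compound 2 (2.30 log units; beyond the scatter), concerns a shortening of the chain and not the ring, so no measured step bears directly on this change. Compound 4 is therefore expected to sit close to compound 3, with a 1.7-fold lower number from compound 3 to compound 4 (0.24 log units; within the scatter) not beyond the scatter. The estimate for compound 4 in this assay is 250 nM, within the range 60 nM to 1000 nM.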

Compound 4, half-maximal inhibitory concentration: 3250 nM
Compound 4: the middle estimate sits 13-fold (1.11 log units) below what was measured; measured number outside the range, above it.
By their numbers in this assay, from the lowest: compound 2; then compound 3; then compound 4. At a limit, below all of these: compound 1.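

In this assay, for the compounds shown here, the chloro group that is para to the 3-(methyl(propargyl)amino)propoxy group proves to count, a ring change the earlier compounds could not address: with hydrogen in its place there is a 7.6-fold higher number from compound 3 to compound 4 (0.88 log units; beyond the scatter). Compound 4 also extends the chain comparison on the ring with a single chloro group, with a 160-fold higher number from compound 2 to compound 4 (2.21 log units; beyond the scatter) and an at least 32000-fold higher number from compound 1 to compound 4 (4.51 log units; beyond the scatter), so that among compound 1, compound 2 and compound 4 inhibition weakens with each shortening of the chain, and none of these three goes against that order. Compound 1 stands at a limit of the assay and not at a number: the limit of < 0.1 nM in this assay, at which 1 of the 4 values shown sits.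

From the compounds shown here alone, whether this second chloro group would have a step of the same size on the longer chains of compound 1 and compound 2 remains open. So does the effect of a fluoro or a methyl group at this aromatic carbon, or of a longer chain than that of compound 1.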